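What Losing One Methyl Might Do to Cytotoxicity

The compounds below may be only part of what the source reports. "The series", "measured", "known", "first", "only" and "open" are said of these compounds alone.

Compound 1 `Nc1ccn([C@@H]2CC(F)(F)[C@H](CO)O2)c(=O)n1`: > 100000 nM
Compound 2 `Cc1cn([C@@H]2CC(F)(F)[C@H](CO)O2)c(=O)nc1O`: > 100000 nM

Both compounds were tested in a functional assay on CCRF-CEM cells (Homo sapiens) for cytotoxicity; on this read-out higher numbers stand for weaker inhibition and lower numbers for stronger inhibition. In this assay, compound 2 gives > 100000 nM, which is a limit of the assay and not a number. Compound 1 gives > 100000 nM, and this too is a limit and not a number. The two readings coincide: the limit of > 100000 nM in this assay, at which 2 of the 2 values shown sit. Compound 2 therefore has a ceiling rather than an exact position on the scale, and neither compound can be ranked against the other.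

The next compound, compound 3 `O=c1nc(O)ccn1[C@@H]1CC(F)(F)[C@H](CO)O1`, differs from compound 2 at one place, with hydrogen in place of methyl on an aromatic carbon. For the measured compounds named here, no measured pair shows what this exchange does in this assay, so any forecast is tentative. The expectation is for no step beyond the usual scatter, and no direction is favoured. The expected step is a number no higher from compound 2 to compound 3 (the limit leaves the size open). Compound 3 will quite likely be reported only as a limit again. For compound 3 the estimated value is 100000 nM, with an expected range from 40000 nM to 200000 nM.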

Compound 3, half-maximal inhibitory concentration: > 100000 nM
Compound 3: no number, only a limit; the forecaster's own chance of this, stated with the estimate: 85%; the middle value lies on the limit itself.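

In this assay compound 3 gives > 100000 nM, again a limit and not a number. The steps to compound 3 from compound 2 and from compound 1 therefore cannot be read, and all three compounds rest at one shared limit: the limit of > 100000 nM in this assay, at which 3 of the 3 values shown sit.

Still open, from the compounds shown here alone, is how far apart these three compounds truly stand, and whether either exchange alters cytotoxicity at all.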